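Capping the Side-Chain Hydroxyl of Compound 1

The source may hold more compounds than are shown below. What is called first, only, known or untested is meant among the compounds shown, and "the series" means these compounds.

Compound 1 `CC(C)=CC[C@@H](OC[C@H](C)O)C1=CC(=O)c2c(O)ccc(O)c2C1=O` gives 40300 nM in a functional assay on HeLa cells (Homo sapiens) for cytotoxicity, read by MTT assay (a lower number here means a stronger inhibitor, a higher number a weaker inhibitor), the second highest of the three numbers measured. Compound 2 `CC(C)=CC[C@@H](OC(=O)C1CCCO1)C1=CC(=O)c2c(O)ccc(O)c2C1=O` gives 17000 nM, and compound 3 `CCC(O)(CC)CC(=O)O[C@H](CC=C(C)C)C1=CC(=O)c2c(O)ccc(O)c2C1=O` gives 52000 nM. Compound 4 `CC(=O)OC(C)CO[C@H](CC=C(C)C)C1=CC(=O)c2c(O)ccc(O)c2C1=O` differs from compound 1 by 1-acetoxyethyl in place of 1-hydroxyethyl on a saturated chain carbon bound to an oxygen on a saturated carbon. Of the measured steps, a 2.4-fold lower number from compound 1 to compound 2 (0.37 log units; beyond the scatter) and a 1.3-fold higher number from compound 1 to compound 3 (0.11 log units; within the scatter) both alter the same side chain, yet neither keeps the 2-hydroxypropyl while removing its hydrogen-bond donor, so they bear only loosely on this change. Since side-chain changes moved the number modestly at most, the step of a 1.3-fold lower number from compound 1 to compound 4 (0.13 log units; within the scatter) is expected to be small, within the scatter or slightly downward. Compound 4 is therefore estimated at 30000 nM, with a range from 12000 nM to 70000 nM.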

Compound 4, half-maximal inhibitory concentration: 40100 nM
Beside the measured number, compound 4's estimate is 1.3-fold (0.13 log units) below it, within the range that was stated.
By their numbers in this assay, from the lowest: compound 2; then compounds 4, 1 and 3 (each within the scatter of the next).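

In this assay, acetylating the side-chain hydroxyl leaves the number where it was, with a 1.0-fold lower number from compound 1 to compound 4 (0.00 log units; within the scatter) as the step, so at this position losing the hydrogen-bond donor of 2-hydroxypropyl shows no measurable cost. The acetate also sits level with the ester side chain, at a 1.3-fold lower number from compound 3 to compound 4 (0.11 log units; within the scatter) as the step, whereas a 2.4-fold higher number from compound 2 to compound 4 (0.37 log units; beyond the scatter) shows that compound 2 keeps its lower number against compound 4 as well. No evidence here explains why the acetyl cap changes so little.

From the compounds shown here alone, whether an amine or a carboxylic acid at this place would move the number remains open. So does whether a longer chain on the acetate would stay level with compound 1.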